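This account rests on a few compounds, and the source may have more. Where it says the series, first, only, none or still open, it means among the compounds named here.

Measured compounds, with their values in an ADME assay on MT4 cells (Homo sapiens) for cytotoxicity, read by MTT assay, with a stated time of 5 days; a lower number here means that less compound is tolerated, a higher number that more compound is tolerated:
compound 1, `C=CCN1C(=O)N(Cc2ccccc2)S(=O)(=O)n2cccc21`: > 802000 nM
compound 2, `O=C1N(Cc2ccccc2Br)c2cccn2S(=O)(=O)N1Cc1ccccc1`: 226000 nM
compound 3, `O=C1N(C/C=C/c2ccccc2)c2cccn2S(=O)(=O)N1Cc1ccccc1`: > 318000 nM

Compound 3 stands at a limit of this assay rather than at a number; its value of > 318000 nM is a limit (the limit of > 318000 nM in this assay, at which 1 of the 3 values shown sits). The value of compound 1 is likewise a limit (the limit of > 802000 nM in this assay, at which 1 of the 3 values shown sits). Only compound 2 gives a plain number in this assay, 226000 nM. The measured steps read as follows: an at least 3.5-fold lower number from compound 1 to compound 2 (0.55 log units; beyond the scatter); an at least 1.4-fold higher number from compound 2 to compound 3 (0.14 log units; that floor lies within the scatter); and a step that the two limits leave unreadable from compound 1 to compound 3. Two of the three values sitting at limits leave the series thinly resolved.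

Compound 4 is `O=C1N(Cc2ccc(F)cc2)c2cccn2S(=O)(=O)N1Cc1ccccc1`, not yet measured. 4-fluorophenyl in place of 2-phenylethenyl on a saturated chain carbon bound to an amide-type nitrogen in a ring The step that bears most on it is an at least 1.4-fold higher number from compound 2 to compound 3 (0.14 log units; that floor lies within the scatter), since compound 2 carries a halogen-bearing phenyl at the same place and gives a value of 226000 nM. Compound 3, by contrast, returns only a limit. The step of an at least 3.5-fold lower number from compound 1 to compound 2 (0.55 log units; beyond the scatter) shows that an aryl group at this place can bring the number down to a readable value. Compound 4 is therefore expected to show no step beyond the scatter, an at least 1.0-fold lower number from compound 3 to compound 4 (0.02 log units; that floor lies within the scatter), and may well return only a limit again. Compound 4 is estimated at 300000 nM, with a range from 150000 nM to 800000 nM.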

Compound 4, half-maximal cytotoxic concentration: 150000 nM
The estimate for compound 4 lay 2.0-fold (0.30 log units) above the measured number; the range from low to high includes it.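

Within the data shown here, the change to 4-fluorophenyl in this assay gives an at least 2.1-fold lower number from compound 3 to compound 4 (0.32 log units; beyond the scatter), the first step beyond the scatter against 2-phenylethenyl at this place, where compound 2 with its 2-bromophenyl gave only a floor within the scatter. Among these compounds, the two halogen-bearing phenyl groups are not told apart in this read-out: a 1.5-fold lower number from compound 2 to compound 4 (0.18 log units; within the scatter) is the step between them, so the readable numbers of the series so far come from these two compounds and show no dependence on which of the two groups is present. Against vinyl the same place gives an at least 5.3-fold lower number from compound 1 to compound 4 (0.72 log units; beyond the scatter), so compound 4 now joins compound 2 in lying beyond the scatter from compound 1, and the lower tolerated concentration at this place no longer rests on compound 2 alone.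

As far as these compounds go, whether an unsubstituted benzyl, an amine or a carboxylic acid on the phenyl ring, or a longer chain to the ring would stay with compounds 2 and 4 remains open. The full size of the step to compound 4 also remains open, as compound 3 gives a limit and not a number: the limit of > 318000 nM in this assay, at which 1 of the 4 values shown sits.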